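Swapping chloro for bromo: cytotoxicity on Vero cells

The compounds below may be only part of what the source reports. "The series", "measured", "known", "first", "only" and "open" are said of these compounds alone.

Measured so far:
compound 2, `Cc1ccc(NCc2cn(-c3ccccc3)nc2-c2ccc(Cl)cc2)cc1`, > 100000 nM
compound 1, `FC(F)(F)c1ccc(NCc2cn(-c3ccccc3)nc2-c2ccc(Br)cc2)cc1`, 28000 nM
compound 3, `Clc1ccc(NCc2cn(-c3ccccc3)nc2-c2ccc(Br)cc2)cc1`, 43000 nM; > 100000 nM (2 entries)

Of the compounds shown here, three sharing one core have been tested in an ADME assay on Vero 76 cells (Chlorocebus sabaeus) for cytotoxicity, read by MTT assay, with a stated time of 96 h; a lower number here means that less compound is tolerated, a higher number that more compound is tolerated. For compound 2 the result is a limit of the assay rather than a number, > 100000 nM. Compound 2 thus stands at the edge of what the measurements can show, with no single value attached to it. Compound 1 gives a number, 28000 nM. Compound 3 has been run more than once, and its results are spread, as seen in the several entries of compound 3 in this assay, 43000 nM; > 100000 nM (2 entries), which also shows that a reading can sit at the limit of > 100000 nM in this assay, at which 1 of the 3 values shown sits.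

Compound 4 is `Cc1ccc(NCc2cn(-c3ccccc3)nc2-c2ccc(Br)cc2)cc1`, not yet measured in this assay. It differs from compound 2 by bromo in place of chloro on an aromatic carbon. For the measured compounds named here, no two measured compounds differ from each other in one place only, so no measured step of this kind is available here, and the spread within compound 3 leaves the direction open.

The step of an at least 1.4-fold lower number from compound 2 to compound 4 (0.15 log units; that floor lies within the scatter) is therefore expected to stay within the usual scatter, with no clear direction. Compound 4 is expected to give about 70000 nM, with a range from 25000 nM to 200000 nM.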

Compound 4, half-maximal cytotoxic concentration: > 100000 nM
Compound 4 ended at the assay's limit; the forecaster's own chance of this, stated with the estimate: 50%; middle value at least 1.4-fold (0.15 log units) from the limit.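

Compound 4 and compound 2 both end at the assay's limit, so the step between them, bromo in place of chloro on an aromatic carbon, cannot be read in size or direction. What the result does show is that this position can carry bromo as well as chloro with methyl on the other aromatic ring, without a number appearing under the limit in this assay. For the compounds shown here, it also gives the first readable step in this set, at a different place, where methyl in place of trifluoromethyl on an aromatic carbon gives an at least 3.5-fold higher number from compound 1 to compound 4 (0.55 log units; beyond the scatter), so the more tolerated side of that change is now visible.

The compounds shown leave open how the 4-chlorophenyl to 4-bromophenyl change would read in a pair with numbers under the limit, and how fluoro or methoxy at the same position would compare. They also leave open how close to the limit compounds of this kind really lie, since repeat readings of one compound fall on both sides of it: the several entries of compound 3 in this assay, 43000 nM; > 100000 nM (2 entries)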